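Sulfonamide aryl series: isopropoxycarbonyl replaced by phenyl

A few compounds are considered here, and "the series" means these few. Any claim that something is new, unique, unknown or untested is made for them only; others in the source may bear on it.

Two members of the series have numbers in a functional assay on aorta for antagonist activity at Voltage-gated L-type calcium channel (Rattus norvegicus) (on this read-out higher numbers stand for weaker inhibition and lower numbers for stronger inhibition), so far. Compound 1 `CC(C)OC(=O)CN(c1cccc(Cl)c1)S(=O)(=O)c1cccc(NC(=O)CN(C)C(=O)OCc2ccccc2)c1` gives 15000 nM and stands as the lowest of the two, with compound 2 `CC(C)OC(=O)CN(c1cccc(Cl)c1)S(=O)(=O)c1cccc(NC(=O)CCNC(=O)OCc2ccccc2)c1` giving 17000 nM in this assay; the step of a 1.1-fold higher number from compound 1 to compound 2 (0.05 log units; within the scatter) lies within the scatter. Compound 3 `CN(CC(=O)Nc1cccc(S(=O)(=O)N(Cc2ccccc2)c2cccc(Cl)c2)c1)C(=O)OCc1ccccc1` carries the same core as compound 1, and the change is phenyl in place of isopropoxycarbonyl on a saturated chain carbon bound to a sulfonamide nitrogen. Among the compounds with values here, the only measured step, from compound 1 to compound 2, concerns the chain carbon bound to the carbonyl carbon and not the sulfonamide nitrogen, so it offers no direct guide to the new change; it shows only that one exchange left this assay unmoved. Within the data shown here, with no step at the relevant place, no shift beyond the scatter is expected, and the estimated step of a 1.2-fold lower number from compound 1 to compound 3 (0.06 log units; within the scatter) is set near zero with a wide range. Compound 3 is accordingly expected to give about 13000 nM in this assay, within 3000 nM to 50000 nM.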

Compound 3, half-maximal inhibitory concentration: 12000 nM
The estimate for compound 3 lay 1.1-fold (0.03 log units) above the measured number; the range from low to high includes it.
By their numbers in this assay, from the lowest: compounds 3, 1 and 2 (each within the scatter of the next).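

Phenyl in place of isopropoxycarbonyl on a saturated chain carbon bound to a sulfonamide nitrogen gives a 1.3-fold lower number from compound 1 to compound 3 (0.10 log units; within the scatter) in this assay. Within the data shown here, this is the first reading at this place, and the number stays within the scatter although the 2 hydrogen-bond acceptors of isopropoxycarbonyl leave and a six-membered aromatic ring of carbon only enters, with 6 heavy atoms on each side. No measured evidence bears on this result.

As far as these compounds go, whether a carboxylic acid or an amine in place of isopropoxycarbonyl, or a longer chain in place of benzyl, would move the number beyond the scatter stays open. The compounds shown therefore do not yet identify any change at this place that alters inhibition in this assay.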